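The source may hold more compounds than are shown below. What is called first, only, known or untested is meant among the compounds shown, and "the series" means these compounds.

Measured so far:
compound 1 `c1ccc2c(c1)CCC2NC1CCN(CCCc2c[nH]c3ccc(-n4cnnc4)cc23)CC1` with 68%
compound 2 `C[C@@H](NC1CCN(CCCc2c[nH]c3ccc(-n4cnnc4)cc23)CC1)c1ccccc1` with 90%
compound 3 `NC(=O)OC[C@H](NC1CCN(CCCc2c[nH]c3ccc(-n4cnnc4)cc23)CC1)c1ccccc1` with 73%

In a functional assay on CHO cells for activation of 5-hydroxytryptamine receptor 1D (Homo sapiens), read by GTPgammaS binding (a higher number here means a larger maximal response, a lower number a smaller maximal response), compound 3 stands second highest of the three: its value and that of compound 1 lie within the scatter, while compound 2 sits higher by a number 17 percentage points lower from compound 2 to compound 3 (beyond the scatter) in the reverse direction. Compound 4 `CC(=O)Nc1ccc(CNC2CCN(CCCc3c[nH]c4ccc(-n5cnnc5)cc34)CC2)cc1` differs from compound 3 by 4-acetamidobenzyl in place of 2-(carbamoyloxy)-1-phenylethyl on an amine nitrogen. Among the compounds with values here, two measured steps touch the same amine nitrogen: the step of a number 22 percentage points higher from compound 1 to compound 2 (beyond the scatter) was modest, and the step of a number 5 percentage points higher from compound 1 to compound 3 (within the scatter) stayed within the scatter. Since all three measured values cluster in a narrow band, a small change, if any, is expected, and compound 4 is estimated at 78% (range 62% to 94%), meaning an expected step of a number 5 percentage points higher from compound 3 to compound 4 (within the scatter).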

Compound 4, largest response reached (reported as efficacy), in percent of the reference or control that the assay uses: 75%
For compound 4 the middle estimate is 3 percentage points above the measured one; the measured number falls inside the stated range.
By their numbers in this assay, from the lowest: compounds 1, 3 and 4 (each within the scatter of the next); then compound 2.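

In this assay the 4-acetamidobenzyl group, which has no defined stereocentre, falls in with the two groups already close together on this amine nitrogen, with a step of a number 2 percentage points higher from compound 3 to compound 4 (within the scatter) and a step of a number 7 percentage points higher from compound 1 to compound 4 (within the scatter). Only 1-phenylethyl stands apart, with a step of a number 15 percentage points lower from compound 2 to compound 4 (beyond the scatter). Nothing available explains this difference. As far as these compounds go, it remains open whether a plain benzyl group or a 4-aminobenzyl group on this nitrogen would stay with compound 4 or come closer to compound 2.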